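Nitro on the aromatic ring of a sulfonamide-linked core

The source may hold more compounds than are shown below. What is called first, only, known or untested is meant among the compounds shown, and "the series" means these compounds.

Measured so far:
compound 1 `COc1cccc2c1CCCC(NCCN1CCC(CNS(=O)(=O)c3cccc4ccccc34)CC1)C2` — > 1000 nM in an assay on isolated protein for inhibition of Neuropeptide Y receptor type 5 (Homo sapiens); on this read-out higher numbers stand for weaker inhibition and lower numbers for stronger inhibition
compound 2 `O=S(=O)(NCCN1CCC(CNC2CCCc3ccccc3C2)CC1)c1cccc2ccccc12` — 210 nM
compound 3 `COc1cc2c(cc1OC)CC(NCC1CCN(CCNS(=O)(=O)c3cccc4ccccc34)CC1)CCC2` — 68 nM

All three share the same sulfonamide–piperidine–amine chain and a benzo-fused saturated ring; they differ only in what sits on the aromatic ring of that core. For compound 1, which carries a methoxy group there, this assay reports only a limit, > 1000 nM. Among the two real numbers, compound 2, with an unsubstituted aromatic ring, gives 210 nM and stands as the higher of the two. Compound 3, which carries two methoxy groups, gives 68 nM, a lower number by a margin beyond the usual scatter, so substitution on that ring can help, while compound 1 shows it can also hurt.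

Compound 4 `O=[N+]([O-])c1ccc2c(c1)CC(NCC1CCN(CCNS(=O)(=O)c3cccc4ccccc34)CC1)CCC2` has not been measured. It differs from compound 2 by nitro in place of hydrogen on an aromatic carbon. For the measured compounds named here, no pair of measured compounds carries this change, so its size cannot be read off directly; the two methoxy examples point in opposite directions. A modest step either way, not clearly beyond the scatter, is the expectation, with the estimated step from compound 2 to compound 4 being a 1.2-fold lower number from compound 2 to compound 4 (0.09 log units; within the scatter). Compound 4 is therefore estimated at 170 nM, with a range from 45 nM to 700 nM.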

Compound 4, half-maximal inhibitory concentration: 79 nM
For compound 4 the middle estimate is 2.2-fold (0.33 log units) above the measured one; low and high end bracket the measured number.
By their numbers in this assay, from the lowest: compounds 3 and 4 (each within the scatter of the next); then compound 2. At a limit, above all of these: compound 1.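

In this assay, for the compounds shown here, this pair gives the first clean reading of a single change on the shared core: replacing hydrogen with nitro produces a 2.7-fold lower number from compound 2 to compound 4 (0.42 log units; beyond the scatter), a modest step that means stronger inhibition. Going by these compounds alone, this aromatic carbon, meta to a fused ring and para to a fused ring, therefore accepts a group of three heavy atoms, with two hydrogen-bond acceptors and no net charge, without any loss of inhibition; the earlier compounds differed in more than one place, so they could not isolate this position or this change. Nothing measured here accounts for the gain, so the step stands as an observation without an explanation.

From the compounds shown here alone, it remains open whether the gain is particular to nitro or would also appear with another group on the same carbon, such as an amine, a nitrile or a carboxylic acid. Also unresolved is whether nitro would give a similar step on a different aromatic carbon of this ring, or on the same carbon of a core with other substituents.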